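A Chloro Substituent Added to the Urea Side Chain

The source may report more compounds than this note shows. Statements on the series, on what has been measured and on what is new or still open speak of the compounds shown alone.

Of the compounds shown here, three built on one shared core have been measured in a functional assay on 786-0 cells (Homo sapiens) for inhibition, read by sulforhodamine B assay, with a stated time of 48 h; a lower number here means a stronger inhibitor of growth, a higher number a weaker inhibitor of growth. Compound 3 `COc1cc(-c2nn(-c3cccc(NC(=O)Nc4cccc(C(F)(F)F)c4)c3)cc2-c2ccncc2)ccc1Cl` gives 4050 nM. Compound 1 `COc1cc(-c2nn(-c3cccc(NC(=O)Nc4cc(C(F)(F)F)cc(C(F)(F)F)c4)c3)cc2-c2ccncc2)ccc1Cl` gives 2020 nM. Compound 2 `COc1cc(-c2nn(-c3cccc(NC(=O)c4cccc(C(F)(F)F)c4)c3)cc2-c2ccncc2)ccc1Cl` gives only a limit of the assay, > 50000 nM. Among the two real numbers, compound 3 holds the higher one, with compound 1 nearest to it: a 2.0-fold higher number from compound 1 to compound 3 (0.30 log units; within the scatter). The other step, an at least 12-fold lower number from compound 2 to compound 3 (1.09 log units; beyond the scatter), shows how much the linking group between the two aromatic rings matters, though it is read against a limit, (the limit of > 50000 nM in this assay, at which 1 of the 3 values shown sits).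

Compound 4 `COc1cc(-c2nn(-c3cccc(NC(=O)Nc4ccc(Cl)c(C(F)(F)F)c4)c3)cc2-c2ccncc2)ccc1Cl` differs from compound 3 in one place: chloro in place of hydrogen on an aromatic carbon. Among the measured compounds shown here, no measured step adds a chloro group, so the closest guide is the exchange of a hydrogen for a trifluoromethyl on the same six-membered aromatic ring, a 2.0-fold higher number from compound 1 to compound 3 (0.30 log units; within the scatter), which stayed within the scatter. A small group added to this ring has so far moved the number little, so a similarly modest shift, downward or none at all, is expected here. The step from compound 3 to compound 4 is estimated as a 2.0-fold lower number from compound 3 to compound 4 (0.31 log units; beyond the scatter). Compound 4 is therefore expected to give about 2000 nM in this assay, within a range from 800 nM to 5000 nM.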

Compound 4, concentration for total growth inhibition: 8020 nM
Estimate against measurement, compound 4: 4.0-fold (0.60 log units) below, and the stated range ends below it.
By their numbers in this assay, from the lowest: compounds 1, 3 and 4 (each within the scatter of the next, the first and the last beyond it). At a limit, above all of these: compound 2.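

Chloro on this carbon, ortho to a trifluoromethyl group and para to a large group, gives a 2.0-fold higher number from compound 3 to compound 4 (0.30 log units; within the scatter), so compound 3 and compound 4 cannot be told apart in this assay. The earlier step on this ring, a 2.0-fold higher number from compound 1 to compound 3 (0.30 log units; within the scatter), concerned a trifluoromethyl group at another carbon; this result adds a second position and a different group, and here too the change stays within the scatter, so the ring bearing the urea accepts an added chloro with no measurable effect on the number. The urea compound 4 also remains clearly separated from the amide compound 2, at an at least 6.2-fold lower number from compound 2 to compound 4 (0.79 log units; beyond the scatter), although this step is read against a limit and not against a real number: the limit of > 50000 nM in this assay, at which 1 of the 4 values shown sits.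

As far as these compounds go, whether a fluoro group, a nitrile or an amine on this same carbon would move the number beyond the scatter remains open. Also open, from the compounds shown here alone, is how chloro would behave on the ring of compound 1, which carries two trifluoromethyl groups, since a single pair cannot show whether the result holds on another substitution pattern.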